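This account rests on a few compounds, and the source may have more. Where it says the series, first, only, none or still open, it means among the compounds named here.

Measured so far:
- compound 1, `CN1CCN(c2ccc([N+](=O)[O-])c(Nn3cccc3)c2)CC1`: 481 nM
- compound 2, `O=[N+]([O-])c1ccc(N2CCNCC2)cc1NCCOc1ccc(Cl)cc1`: 290 nM

In an assay on HEK293 cells for displacement of a labelled ligand from 5-hydroxytryptamine receptor 6 (Homo sapiens) (on this read-out lower numbers stand for stronger inhibition and higher numbers for weaker inhibition), compound 1 gives 481 nM, the higher of the two numbers shown. Compound 2 in this assay gives 290 nM, and the gap between the two compounds lies within the scatter, so the two values cannot be told apart. Within the data shown here, no step between two measured compounds that differ in a single place is available, so the change toward compound 3 rests on the structures alone.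

Compound 3, `CC(Nc1cc(N2CCN(C)CC2)ccc1[N+](=O)[O-])c1ccccc1`, differs from compound 1 by 1-phenylethyl in place of 1H-pyrrol-1-yl on a nitrogen on an aromatic ring. The entering group is an open, carbon-only substituent rather than a second small aromatic ring on the same nitrogen, a change whose effect in this assay is not anchored by any measured pair. The step of a 1.9-fold lower number from compound 1 to compound 3 (0.27 log units; within the scatter) is expected to stay within or only slightly beyond the scatter, with any shift more likely toward a lower number. Compound 3 is therefore estimated at 260 nM, in a range from 60 nM to 1100 nM.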

Compound 3, inhibition constant: 12 nM
The estimate for compound 3 lay 22-fold (1.34 log units) above the measured number, and the stated range ends above it.
By their numbers in this assay, from the lowest: compound 3; then compounds 2 and 1 (each within the scatter of the next).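

In this assay, the substituent on a nitrogen on an aromatic ring proves to matter: 1-phenylethyl in place of 1H-pyrrol-1-yl gives a 40-fold lower number from compound 1 to compound 3 (1.60 log units; beyond the scatter) on the otherwise shared core. Among these compounds, the earlier compounds offered no pair differing in one place, so this is the first sign that the read-out responds to a change at this position, and the response is large. Nothing available explains why this replacement has so large an effect.

A single step cannot show whether the gain follows the six-membered aromatic ring of carbon only or the methyl carried by 1-phenylethyl. Benzyl, which lacks that methyl, or a longer 2-phenylethyl chain on the same nitrogen would separate the two, and whether other aromatic rings, such as pyridyl, serve equally well also remains open.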